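A Single Ring Stereocentre Inverted

The compounds below may be only part of what the source reports. "The series", "measured", "known", "first", "only" and "open" are said of these compounds alone.

Compound 1: `C#CC[C@H]1C[C@H](n2cccc2C(C)=O)C(=O)O1`, in a functional assay on N2a cells (Mus musculus), with a stated time of 48 h, tested at 0.01 uM (on this read-out lower numbers stand for a weaker effect and higher numbers for a stronger effect at the one concentration tested), compound 1 gives 9.04%.
Compound 2: `C#CC[C@@H]1C[C@H](n2cccc2)C(=O)O1`, in this assay compound 2 gives 6.56%.

Of the two numbers shown, compound 2 holds the lower one, yet its gap to compound 1 lies within the usual scatter, so the two compounds cannot be told apart on this read-out; both sit low. Compound 3 is `C#CC[C@H]1C[C@H](n2cccc2)C(=O)O1`, not yet measured. It differs from compound 2 as follows: the two compounds have the same atoms and bonds and differ only in configuration as drawn: 1 of 2 stereo elements differ; a stereocentre at a saturated ring carbon is drawn R in compound 2 and S in compound 3.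

For the measured compounds named here, no step between measured compounds is available to guide this change, and nothing among the two measured values points to a large effect of such an inversion. The step from compound 2 to compound 3 is therefore expected to be small, around a number 1.4 percentage points higher from compound 2 to compound 3 (within the scatter), and not beyond the scatter in either direction. Compound 3 is estimated at 8% in this assay, within a range from 0% to 20%.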

Compound 3, a percentage reported as activity, at one concentration (the size of the read-out at that concentration, not a potency): 12.2%
Compound 3: the middle estimate sits 4.2 percentage points below what was measured; the measured number falls inside the stated range.
By their numbers in this assay, from the lowest: compounds 2, 1 and 3 (each within the scatter of the next).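

In this assay, for the compounds shown here, inverting the stereocentre at a saturated ring carbon gives a number 5.6 percentage points higher from compound 2 to compound 3 (within the scatter), so this inversion produces no step that can be told from the scatter on this read-out. That step can be read as one of configuration alone: the fact that compounds 2 and 3 differ only in the configuration as drawn. Hydrogen in place of acetyl on an aromatic carbon gives a number 3.2 percentage points higher from compound 1 to compound 3 (within the scatter), so on this read-out, at this one concentration, the acetyl group is likewise not shown to matter.

From the compounds shown here alone, whether an amine or a carboxylic acid in place of acetyl on that aromatic carbon would give a step beyond the scatter remains open. So does the effect of inverting the second stereo element, which is drawn alike in compound 1, compound 2 and compound 3.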